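The source may report more compounds than this note shows. Statements on the series, on what has been measured and on what is new or still open speak of the compounds shown alone.

Measured in an ADME assay on microsomes from liver (Homo sapiens) for metabolic stability, tested at 2.5 uM; a lower number here means slower removal, a higher number faster removal of the compound:
compound 1 `COc1cccc(-c2c(S(=O)(=O)c3ccc(C)c(F)c3)cnc3c(F)cccc23)c1`, 4.02 mL/min
compound 2 `COc1ccc(-c2c(S(=O)(=O)c3ccc(C)c(F)c3)cnc3c(F)cccc23)cc1`, 3.27 mL/min
compound 3 `COc1cccc(-c2c(S(=O)(=O)c3ccc(F)cc3)cnc3c(F)cccc23)c1`, 2.23 mL/min

Compound 2 differs from compound 1 by 4-methoxyphenyl in place of 3-methoxyphenyl on an aromatic carbon. In this assay that change gave a 1.2-fold lower number from compound 1 to compound 2 (0.09 log units; within the scatter). Compound 3 differs from compound 1 by 4-fluorophenyl in place of 3-fluoro-4-methylphenyl on a sulfonyl sulfur, and in this assay that step was a 1.8-fold lower number from compound 1 to compound 3 (0.26 log units; within the scatter). The three values all lie within the scatter of one another, so no ordering among them can be read.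

Compound 4 `COc1ccc(-c2c(S(=O)(=O)c3ccc(F)cc3)cnc3c(F)cccc23)cc1` has not yet been measured. It differs from compound 3 by 4-methoxyphenyl in place of 3-methoxyphenyl on an aromatic carbon, which is the same change as that from compound 1 to compound 2, here made on the core of compound 3. The step from compound 3 to compound 4 is expected to be small, a 1.2-fold lower number from compound 3 to compound 4 (0.07 log units; within the scatter), because the same change earlier gave a 1.2-fold lower number from compound 1 to compound 2 (0.09 log units; within the scatter). In this assay compound 4 is therefore estimated at 1.9 mL/min, with a plausible range from 1 mL/min to 3.6 mL/min.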

Compound 4, intrinsic clearance in a liver preparation (reported as CLH), per the amount of preparation that the assay uses: 2.41 mL/min
For compound 4 the middle estimate is 1.3-fold (0.10 log units) below the measured one; low and high end bracket the measured number.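

In this assay, 4-methoxyphenyl in place of 3-methoxyphenyl gave a 1.1-fold higher number from compound 3 to compound 4 (0.03 log units; within the scatter), and this step agrees with the same change on the other core: the same change on two cores in this assay, a 1.2-fold lower number (0.09 log units; within the scatter) from compound 1 to compound 2 and a 1.1-fold higher number (0.03 log units; within the scatter) from compound 3 to compound 4, 1.3-fold (0.12 log units) apart, within the scatter of two such steps. On the sulfonyl sulfur, 4-fluorophenyl in place of 3-fluoro-4-methylphenyl gave a 1.4-fold lower number from compound 2 to compound 4 (0.13 log units; within the scatter), which also agrees with its earlier counterpart: the same change on two cores in this assay, a 1.8-fold lower number (0.26 log units; within the scatter) from compound 1 to compound 3 and a 1.4-fold lower number (0.13 log units; within the scatter) from compound 2 to compound 4, 1.3-fold (0.12 log units) apart, within the scatter of two such steps. Each change thus carried across these two cores without a measurable difference, but with every step within the scatter, this shows neither a real effect of either change nor that the agreement would hold on a further core.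

From the compounds shown here alone, whether an amine or a carboxylic acid in place of the methoxy group would move the number beyond the scatter remains open. So does the effect of a longer chain on that oxygen.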